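A few compounds are considered here, and "the series" means these few. Any claim that something is new, unique, unknown or untested is made for them only; others in the source may bear on it.

Compounds measured so far in an ADME assay on HepG2 cells (Homo sapiens) for cytotoxicity, read by CellTiter-Glo, with a stated time of 48 h; on this read-out higher numbers stand for lower toxicity in this test and lower numbers for higher toxicity in this test:

compound 1, `CCCCNc1nc2ccc(OC)cc2nc1S(C)(=O)=O`, gives 20000 nM
compound 2, `CCCCNc1nc2ccccc2nc1S(C)(=O)=O`, gives 12600 nM

Compound 2 stands alongside compound 1: the gap a 1.6-fold lower number from compound 1 to compound 2 (0.20 log units; within the scatter) lies within the scatter, so the two numbers cannot be told apart. Compound 3, `CCCCNc1nc2cc(Br)ccc2nc1S(C)(=O)=O`, keeps the shared core of compound 2 and differs in one place: bromo in place of hydrogen on an aromatic carbon. Going by the values given here, the only measured step, from compound 1 to compound 2, concerns a different group and was itself within the scatter, so nothing measured speaks directly to a bromo group; it only shows that one small change on this aromatic ring left the read-out essentially unchanged. The step in this assay is therefore expected to be a 1.3-fold lower number from compound 2 to compound 3 (0.10 log units; within the scatter), not beyond the scatter. Compound 3 is estimated to give 10000 nM, with a range from 4000 nM to 25000 nM.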

Compound 3, half-maximal cytotoxic concentration: 7940 nM
Compound 3: the middle estimate sits 1.3-fold (0.10 log units) above what was measured, within the range that was stated.
By their numbers in this assay, from the lowest: compounds 3, 2 and 1 (each within the scatter of the next, the first and the last beyond it).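

In this assay the result is a 1.6-fold lower number from compound 2 to compound 3 (0.20 log units; within the scatter), so a single bromine atom in place of hydrogen on this aromatic carbon gives a number that cannot be told apart from that of compound 2. This is a second single change on the six-membered aromatic ring that stays within the scatter, after a 1.6-fold lower number from compound 1 to compound 2 (0.20 log units; within the scatter), and it extends that observation from a methoxy group to a bromo group. Nothing measured here bears on the reason for the size of this step.

Still open, from the compounds shown here alone, is whether an amine, a carboxylic acid or a nitrile on this same carbon would move the number beyond the scatter. The compounds shown also do not tell what a bromo group would do on another carbon of this ring, or what a longer chain would do elsewhere on the shared core.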